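Pyrazoline hydroxyphenyl series: fluorine added beside a moved hydroxyl

The source may hold more compounds than are shown below. What is called first, only, known or untested is meant among the compounds shown, and "the series" means these compounds.

Compound 1: `CC(C)(C)C1=NN(c2cccc(F)c2)C(c2ccc(O)cc2)C1` with 19.3%
Compound 2: `Oc1ccc(C2CC(c3ccccc3)=NN2c2ccc(Cl)cc2)cc1` with 31.6%
Compound 3: `CC(C)(C)C1=NN(c2ccc(Cl)cc2)C(c2cccc(O)c2)C1` with 17.4%

Of the compounds shown here, three have been tested in an assay on isolated protein for inhibition of protein kinase C iota type (Homo sapiens), tested at 20 uM; a lower number here means less inhibition, a higher number more inhibition at the concentration tested (going by the name of the read-out). Compound 3 gives 17.4%, the lowest of the three numbers. Its nearest neighbour is compound 1, whose 19.3% lies within the scatter of repeated measurements, so no order between these two can be read. Compound 2, with 31.6%, stands beyond the scatter above compound 3.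

Compound 4 is `CC(C)(C)C1=NN(c2ccc(Cl)cc2)C(c2ccc(O)c(F)c2)C1` and has not yet been measured. It differs from compound 3 in one place: 3-fluoro-4-hydroxyphenyl in place of 3-hydroxyphenyl on a saturated ring carbon. Compound 1 already carries a 4-hydroxyphenyl group alongside the tert-butyl group and gives a number within the scatter of compound 3, so shifting the hydroxyl alone would not be expected to move the read-out much; what the added fluorine does is not shown by any measured pair.

The step of a number 4.6 percentage points higher from compound 3 to compound 4 (within the scatter) is therefore expected to be small, most likely within the scatter, with a slight lean upward. Compound 4 is estimated to give 22% in this assay, with a range from 8% to 38%.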

Compound 4, a percentage reported as inhibition, at one concentration (the size of the read-out at that concentration, not a potency): 29.7%
Estimate against measurement, compound 4: 7.7 percentage points below; the range from low to high includes it.
By their numbers in this assay, from the lowest: compounds 3 and 1 (each within the scatter of the next); then compounds 4 and 2 (each within the scatter of the next).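

For the compounds shown here, replacing 3-hydroxyphenyl with 3-fluoro-4-hydroxyphenyl on the saturated ring carbon, while the 4-chlorophenyl and tert-butyl groups stay the same, gives in this assay a number 12.3 percentage points higher from compound 3 to compound 4 (beyond the scatter) and so provides the first measured pair, showing that the read-out responds to a change at this position. The replacement does two things at once, adding a fluorine and moving the hydroxyl, and this single pair cannot assign the step to either one. Nothing measured here explains the step.

The compounds shown leave open whether a plain 4-hydroxyphenyl group at this position, with the 4-chlorophenyl and tert-butyl groups kept, would give a number like that of compound 3 or like that of compound 4, which is the comparison needed to separate the hydroxyl move from the fluorine. They also leave open how the read-out would respond if chlorine or methyl took the place of the fluorine, or if a methoxy group, an amine or a carboxylic acid took the place of the hydroxyl.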